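The compounds below may be only part of what the source reports. "The series", "measured", "known", "first", "only" and "open" are said of these compounds alone.

Of the compounds shown here, three sharing one core have been measured in a functional assay on HeLa cells (Homo sapiens) for antiproliferative activity, read by MTT assay, with a stated time of 48 h; on this read-out lower numbers stand for stronger inhibition and higher numbers for weaker inhibition. Compound 1 `C[C@H](NC(=O)c1cc2ccccc2cn1)C(=O)OCc1ccccc1` gives 154 nM. Compound 2 `CC(C)[C@H](NC(=O)c1cc2ccccc2cn1)C(=O)OCc1ccccc1` gives 118 nM, and compound 3 `NC(=O)CC[C@H](NC(=O)c1cc2ccccc2cn1)C(=O)OCc1ccccc1` gives 181 nM. Compound 3 has the highest of these three numbers, though the step of a 1.2-fold higher number from compound 1 to compound 3 (0.07 log units; within the scatter) and the step of a 1.5-fold higher number from compound 2 to compound 3 (0.19 log units; within the scatter) both lie within the scatter, so no real order among the three can be claimed. Compound 4 `O=C(C[C@H](NC(=O)c1cc2ccccc2cn1)C(=O)OCc1ccccc1)OCc1ccccc1` differs from compound 3 by benzyloxycarbonyl in place of carbamoylmethyl on a saturated chain carbon, two bonds along the chain from an amide-type nitrogen and a carbonyl carbon. Changes of the side chain at this place have so far moved little: the steps of a 1.3-fold lower number from compound 1 to compound 2 (0.12 log units; within the scatter) and a 1.2-fold higher number from compound 1 to compound 3 (0.07 log units; within the scatter) stayed within the scatter. The step from compound 3 to compound 4 is therefore expected to stay within the scatter as well, with no set direction, as a 1.1-fold lower number from compound 3 to compound 4 (0.03 log units; within the scatter). Compound 4 is expected to give 170 nM, between 80 nM and 360 nM.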

Compound 4, half-maximal inhibitory concentration: 411 nM
Compound 4: the middle estimate sits 2.4-fold (0.38 log units) below what was measured; the whole stated range lies below it.
By their numbers in this assay, from the lowest: compounds 2, 1 and 3 (each within the scatter of the next); then compound 4.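

Within the data shown here, this position is less tolerant than the earlier compounds suggested: benzyloxycarbonyl is the first group here to move the number beyond the scatter, with a 2.3-fold higher number from compound 3 to compound 4 (0.36 log units; beyond the scatter), a 2.7-fold higher number from compound 1 to compound 4 (0.43 log units; beyond the scatter) and a 3.5-fold higher number from compound 2 to compound 4 (0.54 log units; beyond the scatter). All three steps are modest and point towards weaker inhibition. Nothing measured here explains this shift.

From the compounds shown here alone, whether the weaker inhibition goes with the aromatic ring or with the ester remains open; a carboxylic acid or a methyl ester at this place could help separate the two. Going by these compounds, how an amine or a longer chain would behave here is also open.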